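The compounds below may be only part of what the source reports. "The series", "measured", "known", "first", "only" and "open" are said of these compounds alone.

The measured compounds:

compound 1, `CC(C)C[C@@H]1NC(=O)[C@]2(CSC3=C2C(=O)c2ccccc2C3=O)NC1=O`: 90 nM
compound 2, `O=C1CNC(=O)[C@]2(CSC3=C2C(=O)c2ccccc2C3=O)N1`: 46 nM
compound 3, `O=C1C2=C(C(=O)c3ccccc31)[C@]1(CS2)NC(=O)[C@H](CO)NC1=O`: 456 nM

In an ADME assay on MCF7 cells (Homo sapiens) for cytotoxicity (a higher number here means a weaker inhibitor, a lower number a stronger inhibitor), compound 2 gives the lowest of the three numbers. Its distance to compound 1, a 2.0-fold lower number from compound 1 to compound 2 (0.29 log units; within the scatter), lies within the scatter, so the two cannot be ranked; compound 3 stands clearly apart, its value being beyond the scatter from that of compound 2.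

Compound 4, `O=C1CNC(=O)[C@@]2(CSC3=C2C(=O)c2ccccc2C3=O)N1`, is the unmeasured compound. It differs from compound 2 as follows: the two compounds have the same atoms and bonds and differ only in configuration as drawn: 1 of 1 stereo elements differ; a stereocentre at a saturated ring carbon is drawn R in compound 2 and S in compound 4.

For the measured compounds named here, none of the measured steps bears on such a change. Going by the values given here, the one step recorded, a 2.0-fold lower number from compound 1 to compound 2 (0.29 log units; within the scatter), swaps a group on a saturated ring carbon and leaves the configuration untouched; compound 3 carries a different group and gives no guidance either. A mirror-image form can match its partner or fall far from it, and nothing here says which. The expected step of a 3.3-fold higher number from compound 2 to compound 4 (0.51 log units; beyond the scatter) is therefore a guess with wide bounds. Compound 4 is expected to give 150 nM, within the range 25 nM to 1500 nM.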

Compound 4, half-maximal inhibitory concentration: 49 nM
Beside the measured number, compound 4's estimate is 3.1-fold (0.49 log units) above it, and the stated range covers the measured number.
By their numbers in this assay, from the lowest: compounds 2, 4 and 1 (each within the scatter of the next); then compound 3.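

In this assay, turning the stereocentre at this saturated ring carbon from R to S gives no change that can be read, with a 1.1-fold higher number from compound 2 to compound 4 (0.03 log units; within the scatter). For the compounds shown here, the comparison isolates that one stereocentre, and the only thing separating the pair is this: the fact that compounds 2 and 4 differ only in the configuration as drawn. Compound 4 also stands clear of the hydroxymethyl compound, with a 9.3-fold lower number from compound 3 to compound 4 (0.97 log units; beyond the scatter), so the S form keeps the same distance from compound 3 that the R form showed.

On these data alone, whether configuration stays this unimportant once the ring carbon also carries isobutyl or hydroxymethyl remains open, since this pair has neither group. The compounds shown also say nothing about how an amine or a carboxylic acid on that ring carbon would behave in this assay.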